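A few compounds are considered here, and "the series" means these few. Any claim that something is new, unique, unknown or untested is made for them only; others in the source may bear on it.

Measured compounds in an assay on HEK293 cells for negative allosteric modulation of metabotropic glutamate receptor 5 (Homo sapiens), read by FLIPR; on this read-out lower numbers stand for stronger inhibition and higher numbers for weaker inhibition:
Compound 1 `O=C(c1ccc(F)cc1)N1CC(c2nc(-c3cccc(Cl)c3)no2)C1` gives 4000 nM.
Compound 2 `O=C(C1CCC(F)(F)CC1)N1CC(c2nc(-c3cccc(Cl)c3)no2)C1` gives > 10000 nM, which is a limit of the assay.
Compound 3 `COC1CCCN(C(=O)N2CC(c3nc(-c4cccc(Cl)c4)no3)C2)C1` gives 1830 nM.

All three share the same core and differ only in the group on the carbonyl carbon. Compound 3 holds the lowest of the two numbers shown; its nearest neighbour is compound 1, with a 2.2-fold lower number from compound 1 to compound 3 (0.34 log units; beyond the scatter). The other steps are an at least 2.5-fold higher number from compound 1 to compound 2 (0.39 log units; beyond the scatter) and an at least 5.4-fold lower number from compound 2 to compound 3 (0.73 log units; beyond the scatter); the latter rests on (the limit of > 10000 nM in this assay, at which 1 of the 3 values shown sits), so its size is known only as a floor.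

Compound 4 `CC1CN(C(=O)N2CC(c3nc(-c4cccc(Cl)c4)no3)C2)CC(C)O1` is not yet measured. The change from compound 3 is 2,6-dimethylmorpholin-4-yl in place of 3-methoxypiperidin-1-yl on a carbonyl carbon. The two groups have the same atoms joined differently, and the amide-type nitrogen attached to the carbonyl carbon remains. Within the data shown here, none of the measured steps exchanges one such ring for another; the steps seen so far concern the move from an aryl or cycloalkyl group to the ring-bound nitrogen, and they are modest at most. The move from compound 3 to compound 4 is therefore expected to stay within the scatter or shift weakly toward a higher number, a 1.4-fold higher number from compound 3 to compound 4 (0.15 log units; within the scatter). For compound 4 the estimate in this assay is 2600 nM, with a range from 900 nM to 7500 nM.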

Compound 4, half-maximal inhibitory concentration: 990 nM
Estimate against measurement, compound 4: 2.6-fold (0.42 log units) above; the range from low to high includes it.
By their numbers in this assay, from the lowest: compounds 4 and 3 (each within the scatter of the next); then compound 1. At a limit, above all of these: compound 2.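

Among these compounds, the first exchange of one nitrogen-linked ring for another on the carbonyl carbon gives a 1.8-fold lower number from compound 3 to compound 4 (0.27 log units; within the scatter), so 2,6-dimethylmorpholin-4-yl and 3-methoxypiperidin-1-yl cannot be told apart at this position, even though the ring gains a second hetero atom. Measured against the 4-fluorophenyl group, the new group gives a 4.0-fold lower number from compound 1 to compound 4 (0.61 log units; beyond the scatter), which makes it the second group attached through a ring nitrogen to stand beyond the scatter from compound 1; among the four compounds, none goes against this pattern. Compound 2 stands at a limit of the assay, and an at least 10-fold lower number from compound 2 to compound 4 (1.00 log units; beyond the scatter) therefore gives the size of this step only as a floor: the limit of > 10000 nM in this assay, at which 1 of the 4 values shown sits.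

The compounds shown leave open whether the two methyl groups of compound 4 or the methoxy group of compound 3 contribute anything, as neither unsubstituted morpholin-4-yl nor unsubstituted piperidin-1-yl is among them. They also leave open whether a ring is needed on this nitrogen at all, a question that an open-chain diethylamino group in the same place would address.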